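The source may report more compounds than this note shows. Statements on the series, on what has been measured and on what is new or still open speak of the compounds shown alone.

In a functional assay on A549 cells (Homo sapiens) for inhibition, read by sulforhodamine B assay, with a stated time of 48 h (a lower number here means a stronger inhibitor of growth, a higher number a weaker inhibitor of growth), compound 2 (`C/C=C/C=C/C=C1\[C@H](OC)O[C@](C)(OC)[C@H]1OCc1c(O)cccc1CCC`) gives 16200 nM and compound 1 (`C/C=C/C=C/C=C(\CO)[C@H](OCc1c(O)cccc1CCC)[C@H](C)O`) gives 25600 nM with the two numbers inside the usual scatter of each other. Compound 3 (`C/C=C/C=C/C=C1\CO[C@](C)(OC)[C@H]1OCc1c(O)cccc1CCC`) has hydrogen in place of methoxy on a saturated ring carbon, next to the ring oxygen of a five-membered non-aromatic ring. Within the data shown here, no measured pair differs in one place only, so no measured step guides this change. An estimated step of a 1.1-fold higher number from compound 2 to compound 3 (0.05 log units; within the scatter) is expected to stay within the scatter, with no clear direction. For compound 3 the estimated value is 18000 nM with 7000 nM to 40000 nM as the expected range.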

Compound 3, concentration for 50% growth inhibition: 24300 nM
The estimate for compound 3 lay 1.4-fold (0.13 log units) below the measured number; measured number inside the range.
By their numbers in this assay, from the lowest: compounds 2, 3 and 1 (each within the scatter of the next).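

In this assay, among these compounds, the step of a 1.5-fold higher number from compound 2 to compound 3 (0.18 log units; within the scatter) is the first one-place reading, for hydrogen in place of methoxy on a saturated ring carbon next to the ring oxygen. Removing the methoxy group from this carbon leaves the growth-inhibition reading unresolved from that of the parent, so this pair shows no dependence on that group. No supporting data bear on the reason for this result. Still open, going by these compounds, is whether an amine or a longer chain at this carbon would shift the number beyond the scatter.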